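The source may hold more compounds than are shown below. What is called first, only, known or untested is meant among the compounds shown, and "the series" means these compounds.

Measured so far in a functional assay on T98G cells (Homo sapiens) for cytotoxicity, read by MTT assay, with a stated time of 48 h; on this read-out lower numbers stand for stronger inhibition and higher numbers for weaker inhibition

Compound 1 `CC(=NNC(=S)Nc1ccccc1F)c1ccccn1` gives 3.1 nM
Compound 2 `C/C(=N/NC(=S)Nc1ccccc1F)c1ccccn1` gives 3.1 nM
Compound 3 `C/C(=N\NC(=S)Nc1ccccc1F)c1ccccn1` gives 3.1 nM

Level with compounds 1 and 3, compound 2 stands at 3.1 nM in this assay and is the starting point of this account. Compound 4 `C/C(=N/NC(=S)Nc1ccccc1I)c1ccccn1` has not yet been measured. The change is iodo in place of fluoro on an aromatic carbon.

The measured steps bear on this change only indirectly. On configuration the data show no change at the digits printed from compound 1 to compound 2 (within the scatter) with the fact that one of compounds 1 and 2 is drawn with a defined configuration and the other without, at the place where they differ and then no change at the digits printed from compound 1 to compound 3 (within the scatter) with the fact that one of compounds 1 and 3 is drawn with a defined configuration and the other without, at the place where they differ and finally no change at the digits printed from compound 2 to compound 3 (within the scatter) with the fact that compounds 2 and 3 differ only in the configuration as drawn as the setting of that last step. None of these steps alters the halogen, so none gives a measured size or direction for this exchange. No step beyond the scatter is therefore expected, although the uncertainty remains wide.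

The expectation rests on compound 2 at 3.1 nM and on no measured halogen exchange. The expected step is no change at the digits printed from compound 2 to compound 4 (within the scatter) with no direction assigned. For compound 4 the estimate is 3.1 nM with an expected range from 0.8 nM to 12 nM in this assay.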

Compound 4, half-maximal inhibitory concentration: 8.09 nM
For compound 4 the middle estimate is 2.6-fold (0.42 log units) below the measured one, within the range that was stated.
By their numbers in this assay, from the lowest: compounds 1, 2 and 3 (each within the scatter of the next); then compound 4.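

In this assay, the exchange of fluoro for iodo on an aromatic carbon, ortho to a large group, gives a 2.6-fold higher number from compound 2 to compound 4 (0.42 log units; beyond the scatter). Among the compounds shown here, this is the first step in the set to lie beyond the scatter, as compounds 1, 2 and 3 all carry fluoro and differ only in how the double bond is drawn, so the read-out at this position is now seen to respond to the identity of the halogen, with iodo giving the weaker inhibition of the pair, though only modestly. The available facts on drawn configuration do not touch the halogen, so nothing shown here accounts for this step.

As far as these compounds go, it remains open whether chloro or bromo at the same aromatic carbon would fall between fluoro and iodo, and how a hydrogen, a methoxy group or an amine would compare there. From the compounds shown here alone, it is also open whether an iodo compound would stay level across its double-bond configurations, as the fluoro compounds 1, 2 and 3 do, or whether the same exchange would give a step of similar size at another place on the ring.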